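The source may report more compounds than this note shows. Statements on the series, on what has been measured and on what is new or still open speak of the compounds shown alone.

In an ADME assay on microsomes (Mus musculus) for metabolic stability (a higher number here means faster removal of the compound, a lower number slower removal), compound 3 `CNC(=O)[C@@H]1CCCN1S(=O)(=O)c1ccc(Cl)c(COc2cccc3c(-c4cncn4C)cc(C)nc23)c1Cl` gives 117 mL/min/kg, the lowest of the three numbers. Compound 1 `Cc1cc(C(F)(F)F)c2cccc(OCc3c(Cl)ccc(S(=O)(=O)N4CCCCC4)c3Cl)c2n1` gives 1000 mL/min/kg and compound 2 `Cc1cc(C(F)(F)F)c2cccc(OCc3c(Cl)ccc(S(=O)(=O)N4CCC(CCO)CC4)c3Cl)c2n1` gives 1080 mL/min/kg, both beyond the scatter from compound 3.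

Next in the series is compound 4 `CNC(=O)[C@@H]1CCCN1S(=O)(=O)c1ccc(Cl)c(COc2cccc3c(-c4cccnc4)cc(C)nc23)c1Cl`. The change from compound 3 is pyridin-3-yl in place of 1-methyl-1H-imidazol-5-yl on an aromatic carbon, opposite the ring nitrogen.

Among the compounds with values here, the only measured step is a 1.1-fold higher number from compound 1 to compound 2 (0.03 log units; within the scatter). It concerns 2-hydroxyethyl on a saturated ring carbon, elsewhere in the molecule, so it bears only weakly on this exchange. Compounds 1 and 2 differ from compound 3 in more than one place, so their gap to it cannot be assigned to any single group. Within the data shown here, no measured step covers this exchange, and the anchor is compound 3 at 117 mL/min/kg. The expected result is a 1.5-fold higher number from compound 3 to compound 4 (0.16 log units; within the scatter), an estimated small upward lean with wide uncertainty. For compound 4 the estimated clearance is 170 mL/min/kg, with an expected range of 80 mL/min/kg to 420 mL/min/kg.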

Compound 4, clearance: 700 mL/min/kg
Compound 4: the middle estimate sits 4.1-fold (0.61 log units) below what was measured, outside the stated range (above it).
By their numbers in this assay, from the lowest: compound 3; then compounds 4, 1 and 2 (each within the scatter of the next).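

Working notes: the position opposite the ring nitrogen does not tolerate every aromatic ring equally in this assay. Placing pyridin-3-yl in place of 1-methyl-1H-imidazol-5-yl gives a 6.0-fold higher number from compound 3 to compound 4 (0.78 log units; beyond the scatter), the first step in the series beyond the scatter, even though the groups that leave and enter match in heavy-atom count and neither carries a net charge. No measurement shown here accounts for this difference.

A single exchange at this position cannot show whether the low number of compound 3 is specific to 1-methyl-1H-imidazol-5-yl or extends to other five-membered aromatic rings. A phenyl, pyrimidin-5-yl or 1-methyl-1H-pyrazol-5-yl group at the same aromatic carbon would help separate the effect of ring size from that of the number and placement of ring nitrogens.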